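The source may hold more compounds than are shown below. What is called first, only, known or untested is meant among the compounds shown, and "the series" means these compounds.

Compound 1 `Cc1ccc2cc([C@H](C)Nc3ncnc4[nH]cnc34)c(-c3ccccc3)c(=O)n2c1` carries no result in an ADME assay on microsomes from liver (Mus musculus), read by LC-MS, using NADPH, with a stated time of 30 min, tested at 1 uM; a higher number here means that more of the compound is left, a lower number that less of the compound is left: compound 1 gives "not determined" (no result reported). Among the compounds with values here, compound 2 `C[C@H](Nc1nc(N)ncc1C#N)c1cc2ccc(F)cn2c(=O)c1-c1ccccc1` is thus the only member of the series with a number in that assay; in this assay compound 2 gives 11%. Compound 3 `Cc1nc(N)nc(N[C@@H](C)c2cc3ccc(F)cn3c(=O)c2-c2ccccc2)c1C#N` differs from compound 2 by methyl in place of hydrogen on an aromatic carbon. Within the data shown here, no step between measured compounds exists, so the size of such a move in this assay cannot be read from the series; a change of a number 4 percentage points higher from compound 2 to compound 3 (within the scatter) is expected, not beyond the scatter. For compound 3 the expected value is 15%, between 4% and 35%.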

Compound 3, percent of the compound remaining: 8%
The estimate for compound 3 lay 7 percentage points above the measured number; the range from low to high includes it.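

In this assay, within the data shown here, the change to 2-amino-5-cyano-6-methylpyrimidin-4-yl gives a number 3 percentage points lower from compound 2 to compound 3 (within the scatter), the first step that can be read. Hydrogen and methyl on this aromatic carbon, ortho to a cyano group and opposite the ring nitrogen, cannot be told apart in this read-out, and little of either compound is left. Open, as far as these compounds go, is whether an amine, a methoxy group or a longer chain on the same carbon would leave more of the compound. What lies behind the result also stays open, as no measurement at hand speaks to it.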